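The compounds below may be only part of what the source reports. "The series", "measured", "known", "first", "only" and "open" are said of these compounds alone.

Compound 3 `O=C(/C=C/c1cc(Br)c(O)c(Br)c1)Nc1cc2c(Nc3ccc(F)c(Cl)c3)ncnc2cc1O[C@H]1CCOC1` gives 28800 nM in a functional assay on A549 cells (Homo sapiens) for cytotoxicity, read by MTT assay, with a stated time of 72 h (a lower number here means a stronger inhibitor, a higher number a weaker inhibitor), and holds the highest number of the three measured; compound 1 `O=C(/C=C/c1cccc(Cl)c1Cl)Nc1cc2c(Nc3ccc(F)c(Cl)c3)ncnc2cc1O[C@H]1CCOC1` gives 23200 nM in this assay, while compound 2 `COc1ccc(/C=C/C(=O)Nc2cc3c(Nc4ccc(F)c(Cl)c4)ncnc3cc2O[C@H]2CCOC2)c(OC)c1` gives 9350 nM. The step to compound 4 `COc1ccc(/C=C/C(=O)Nc2cc3c(Nc4ccc(F)c(Cl)c4)ncnc3cc2O[C@H]2CCOC2)cc1` is 4-methoxyphenyl in place of 3,5-dibromo-4-hydroxyphenyl on a double-bonded chain carbon bound to a double-bonded chain carbon. Among the measured compounds shown here, the closest precedent runs the other way: a 3.1-fold higher number from compound 2 to compound 3 (0.49 log units; beyond the scatter), and the methoxy-bearing aryl of compound 2 is the nearest analogue of the 4-methoxyphenyl entering here. The step of a 2.5-fold lower number from compound 1 to compound 2 (0.39 log units; beyond the scatter) also points the same way. A modest move toward a lower number is therefore expected, of about a 2.4-fold lower number from compound 3 to compound 4 (0.38 log units; beyond the scatter). The estimate for compound 4 is 12000 nM, with a range from 5000 nM to 30000 nM.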

Compound 4, half-maximal inhibitory concentration: 3050 nM
Compound 4: the middle estimate sits 3.9-fold (0.59 log units) above what was measured; the whole stated range lies above it.
By their numbers in this assay, from the lowest: compound 4; then compound 2; then compounds 1 and 3 (each within the scatter of the next).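

In this assay, among the compounds shown here, the aryl group on the double-bonded chain carbon spans a wider range than the earlier compounds showed: 4-methoxyphenyl gives a 9.4-fold lower number from compound 3 to compound 4 (0.98 log units; beyond the scatter) and also a 7.6-fold lower number from compound 1 to compound 4 (0.88 log units; beyond the scatter) as well. Hydrogen in place of methoxy on an aromatic carbon gives a 3.1-fold lower number from compound 2 to compound 4 (0.49 log units; beyond the scatter) and the lowest number of the four, so the second methoxy of compound 2 is not required. No measurement given here accounts for these steps.

Going by these compounds, whether the remaining methoxy contributes stays open; an amine or a carboxylic acid in its place on compound 4 would test this.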